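Anilino Swap on a Triazole-Linked Nitrile Core

A few compounds are considered here, and "the series" means these few. Any claim that something is new, unique, unknown or untested is made for them only; others in the source may bear on it.

Compound 1 `C#CCSc1nc(Nc2cccc(Cl)c2)c(C#N)c(-c2ccccc2)n1` gives > 128000 nM
Compound 2 `N#Cc1c(Nc2cccc(Cl)c2)nc(SCc2cn(Cc3ccccc3Cl)nn2)nc1-c1ccccc1` gives 12000 nM

Both were tested in a functional assay on MCF7 cells (Homo sapiens) for inhibition, read by MTT assay, with a stated time of 72 h; a lower number here means a stronger inhibitor, a higher number a weaker inhibitor. The value for compound 1 is a limit of the assay, not a number, as the limit of > 128000 nM in this assay, at which 1 of the 2 values shown sits, records. For the measured compounds named here, compound 2 therefore stands as the only numeric value in the set. Compound 3 `Cc1ccccc1Nc1nc(SCc2cn(Cc3ccccc3Cl)nn2)nc(-c2ccccc2)c1C#N` differs from compound 2 by 2-methylphenyl in place of 3-chlorophenyl on a nitrogen on an aromatic ring. Going by the values given here, no measured step of this kind exists here, so the size of the change is uncertain; a modest shift, or none beyond the scatter, is expected, as a 1.5-fold higher number from compound 2 to compound 3 (0.18 log units; within the scatter) conveys. Compound 3 is estimated at 18000 nM, within 5000 nM to 70000 nM.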

Compound 3, half-maximal inhibitory concentration: 7950 nM
Compound 3: the middle estimate sits 2.3-fold (0.35 log units) above what was measured; low and high end bracket the measured number.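

In this assay, putting 2-methylphenyl in place of 3-chlorophenyl on the nitrogen gives a 1.5-fold lower number from compound 2 to compound 3 (0.18 log units; within the scatter), so the two groups cannot be told apart here. For the compounds shown here, this is the first measured change at this place, and it shows that the chlorine of the 3-chlorophenyl group is not needed for a value of this size in this pair.

From the compounds shown here alone, it remains open whether a ring carrying an amine or a carboxylic acid, or a plain alkyl chain in place of the ring, would read the same. Nothing measured here bears on why these two groups read alike.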